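This account rests on a few compounds, and the source may have more. Where it says the series, first, only, none or still open, it means among the compounds named here.

Working notes on the series. In a functional assay on A549 cells (Homo sapiens) for cytotoxicity, read by MTT assay, with a stated time of 72 h (a lower number here means a stronger inhibitor, a higher number a weaker inhibitor), compound 1 `O=C(CN1CCN(c2nnc(Cc3ccccc3)c3ccccc23)CC1)Nc1ccc(F)c(F)c1` gives 10100 nM as its reading. Compound 2 `Cc1ccccc1NC(=O)CN1CCN(c2nnc(Cc3ccccc3)c3ccccc23)CC1` is recorded as "not active" (no number reported) with no number attached, so it has no exact place on the scale. Compound 3 `O=C(CN1CCN(c2nnc(Cc3ccccc3)c3ccccc23)CC1)Nc1ccc(Br)cc1` awaits measurement. Its change from compound 2 is 4-bromophenyl in place of 2-methylphenyl on an amide-type nitrogen and amounts to 4-bromophenyl in place of 2-methylphenyl on an amide-type nitrogen. Going by the values given here, no measured step covers this change, so its size cannot be derived. A move from no number to a weak but measurable reading is expected, though another result without a number remains possible. Among the compounds with values here, this expectation rests on compound 1 at 10100 nM in this assay as the only numbered neighbour, which also carries halogen on its phenyl group. For compound 3 the estimated value is 12000 nM with an expected range of 4000 nM to 40000 nM in this assay.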

Compound 3, half-maximal inhibitory concentration: 2000 nM
For compound 3 the middle estimate is 6.0-fold (0.78 log units) above the measured one, outside the stated range (below it).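

In this assay the group on the amide-type nitrogen now has a measured effect, with a 5.1-fold lower number from compound 1 to compound 3 (0.70 log units; beyond the scatter) on going to 4-bromophenyl in place of 3,4-difluorophenyl. This place therefore tolerates a change that moves the reading beyond the scatter, and the two halogen-bearing phenyl groups are not interchangeable here. Compound 2, with 2-methylphenyl, has no number, so its step to compound 3 cannot be read, and no evidence bearing on the cause of either difference is available.

Whether the shift belongs to bromine itself or to the pattern of substitution on the phenyl group remains open, since neither unsubstituted phenyl nor 4-chlorophenyl appears among the compounds shown. Going by these compounds, how an amine or a carboxylic acid on that phenyl group would read is also open.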